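Working notes: from 4-fluorophenyl to 4-methylphenyl

The source may hold more compounds than are shown below. What is called first, only, known or untested is meant among the compounds shown, and "the series" means these compounds.

- compound 1 `COc1cc(-c2ccnc3cc(-c4ccc(F)cc4)nn23)cc(OC)c1OC`: 1280 nM
- compound 2 `COc1cc(-c2cc3nccc(-c4c[nH]c5ccccc45)n3n2)cc(OC)c1OC`: > 10000 nM (a limit, not a number)

Among the compounds with values here, in a functional assay on MCF7 cells (Homo sapiens) for inhibition, read by CCK-8 assay, with a stated time of 48 h (a lower number here means a stronger inhibitor, a higher number a weaker inhibitor), compound 1 gives 1280 nM as the only actual number so far. Compound 2 gives > 10000 nM as a limit of the assay and not as a number.

The next compound is compound 3 `COc1cc(-c2ccnc3cc(-c4ccc(C)cc4)nn23)cc(OC)c1OC`, which has methyl in place of fluoro on an aromatic carbon, para to a large group (methyl in place of fluoro on an aromatic carbon). Within the data shown here, no measured step covers this change, so the expectation rests on compound 1 at 1280 nM alone. The expected change is a 1.2-fold higher number from compound 1 to compound 3 (0.07 log units; within the scatter) and would lie within the usual scatter, with no step beyond it anticipated in either direction. For compound 3 the estimated value in this assay is 1500 nM with 450 nM to 5000 nM as the expected range.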

Compound 3, half-maximal inhibitory concentration: 47 nM
Compound 3: the middle estimate sits 32-fold (1.50 log units) above what was measured, and the stated range ends above it.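

In this assay, exchanging 4-fluorophenyl for 4-methylphenyl on the shared core gives a 27-fold lower number from compound 1 to compound 3 (1.44 log units; beyond the scatter). This place, para to a large group, is therefore sensitive to the substituent: one heavy atom replaces one heavy atom, no ring, hydrogen-bond donor, hydrogen-bond acceptor or net charge enters or leaves, and the number still moves well beyond the scatter. Compound 1 and compound 2 alone offered no step to show this, and no measurement at hand accounts for the size of the change.

From the compounds shown here alone, with only fluoro and methyl compared here, it remains open whether the gain is specific to methyl or extends to ethyl, a longer chain, methoxy or chloro. An amine or a carboxylic acid at the same place is also untested in the compounds shown, so the tolerance of this position remains undefined.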